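Glycine Ester to Aspartate Diester on a Shared Core

This account rests on a few compounds, and the source may have more. Where it says the series, first, only, none or still open, it means among the compounds named here.

Compound 1, `O=C(CN(c1ncnc2c1ncn2C1CCCCO1)C1CC1)NCC(=O)OCc1ccccc1`, is one of two compounds tested in a functional assay on the whole organism (Tail, strain ICR) with Mus musculus as the target, in the tail flick test, with a stated time of 90 min, at a dose of 25 umol/kg by the oral route; on this read-out lower numbers stand for a weaker effect and higher numbers for a stronger effect at the one dose given. In this assay compound 1 gives 25.9%, the lower of the two numbers, although the gap to the other lies within the usual scatter. The other compound, compound 2 with the structure `C[C@@H](O)[C@H](NC(=O)CN(c1nc(Cl)nc2[nH]cnc12)C1CC1)C(=O)O`, gives in this assay 35.9%; since the two values fall within the scatter of each other, no order between them can be read. Within the data shown here, no pair of measured compounds differs in one place only, so no measured step is available. Compound 3, `O=C(CN(c1ncnc2c1ncn2C1CCCCO1)C1CC1)N[C@@H](CC(=O)OCc1ccccc1)C(=O)OCc1ccccc1`, has not yet been measured. It differs from compound 1 by (benzyloxycarbonyl)methyl in place of hydrogen on a saturated chain carbon bound to an amide-type nitrogen and a carbonyl carbon. Among the measured compounds shown here, with no comparable step to lean on, the change is expected to produce a step of a number 2.1 percentage points higher from compound 1 to compound 3 (within the scatter), that is, nothing beyond the scatter in either direction. For compound 3 the estimated value in this assay is 28%, with a range from 10% to 50%.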

Compound 3, a percentage reported as activity, at one dose (the size of the read-out at that dose, not a potency): 25.1%
Compound 3: the middle estimate sits 2.9 percentage points above what was measured; measured number inside the range.
By their numbers in this assay, from the lowest: compounds 3, 1 and 2 (each within the scatter of the next, the first and the last beyond it).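

In this assay, among these compounds, (benzyloxycarbonyl)methyl in place of hydrogen on a saturated chain carbon bound to an amide-type nitrogen and a carbonyl carbon gives a number 0.8 percentage points lower from compound 1 to compound 3 (within the scatter), the first measured step in this set. It shows that this position can carry a group of 11 heavy atoms, including a six-membered aromatic ring of carbon only, without a difference beyond the scatter at the one dose tested. No supporting data bear on this result, so it stands without an explanation.

As far as these compounds go, whether a small amine such as aminomethyl or a longer chain such as n-butyl at this carbon would give a step beyond the scatter remains open. A single dose also leaves open whether compound 1 and compound 3 would match at other doses.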